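From compound 3 to compound 4: a side group exchanged

The compounds below may be only part of what the source reports. "The series", "measured", "known", "first", "only" and "open" are said of these compounds alone.

Three compounds share one core and differ only on a saturated chain carbon. In a functional assay on the whole organism (Tail, strain ICR) with Mus musculus as the target, in the tail flick test, with a stated time of 120 min, at a dose of 25 umol/kg by the oral route (a higher number here means a stronger effect of the compound at the dose given, a lower number a weaker effect), compound 1 `O=C(CN(c1nc(Cl)nc2[nH]cnc12)C1CC1)N[C@@H](CC(=O)OCc1ccccc1)C(=O)OCc1ccccc1` gives 12.1%, compound 2 `CC(C)C[C@H](NC(=O)CN(c1nc(Cl)nc2[nH]cnc12)C1CC1)C(=O)OCc1ccccc1` gives 8.58%, and compound 3 `O=C(CN(c1nc(Cl)nc2[nH]cnc12)C1CC1)N[C@@H](CCC(=O)OCc1ccccc1)C(=O)OCc1ccccc1` gives 45.9%, the highest of the three, with a number 33.8 percentage points higher from compound 1 to compound 3 (beyond the scatter) and a number 37.3 percentage points higher from compound 2 to compound 3 (beyond the scatter), both beyond the scatter. Compound 4 `NC(=O)C[C@H](NC(=O)CN(c1nc(Cl)nc2[nH]cnc12)C1CC1)C(=O)OCc1ccccc1` differs from compound 3 in one place: carbamoyl in place of (benzyloxycarbonyl)methyl on a saturated chain carbon, two bonds along the chain from an amide-type nitrogen and a carbonyl carbon. The two measured steps show that arriving at (benzyloxycarbonyl)methyl from benzyloxycarbonyl or from isopropyl raised the read-out strongly, so leaving it again for carbamoyl is expected to lower it well beyond the scatter, a number 30.9 percentage points lower from compound 3 to compound 4 (beyond the scatter). Compound 4 is therefore estimated at 15%, with a range from 3% to 35%.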

Compound 4, a percentage reported as activity, at one dose (the size of the read-out at that dose, not a potency): 15.1%
Compound 4: middle estimate off by 0.1 percentage points, on the low side; the range from low to high includes it.
By their numbers in this assay, from the lowest: compounds 2, 1 and 4 (each within the scatter of the next); then compound 3.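

In this assay, replacing the (benzyloxycarbonyl)methyl group on this saturated chain carbon with the much smaller carbamoyl gives a number 30.8 percentage points lower from compound 3 to compound 4 (beyond the scatter). Compound 4 also sits level with the other two compounds, with a number 6.5 percentage points higher from compound 2 to compound 4 (within the scatter) and a number 3 percentage points higher from compound 1 to compound 4 (within the scatter), so compound 3 alone stands apart among these four compounds. Nothing here explains this pattern.

Still open, as far as these compounds go, is whether compound 3 owes its higher read-out to the longer chain or to its benzyl ester. A carbamoylethyl group or a carboxylic acid on that longer chain would help separate the two.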